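Chloro added to a weak dibromobenzanilide core

This account rests on a few compounds, and the source may have more. Where it says the series, first, only, none or still open, it means among the compounds named here.

Compound 1 `O=C(Nc1cccc(Cl)c1)c1cc(Br)cc(Br)c1O` and compound 2 `O=C(Nc1ccccc1)c1cc(Br)cc(Br)c1` were both tested in an assay on isolated protein for inhibition of thiosulfate sulfurtransferase (Homo sapiens), with a stated time of 60 min, in the absence of a further agent; a lower number here means a stronger inhibitor, a higher number a weaker inhibitor. In this assay compound 1 gives only the limit > 100000 nM, a boundary of the measurement rather than a number. Compound 2 likewise gives only the limit > 100000 nM in this assay. For the measured compounds named here, compound 2 therefore stands at the edge of what this assay reports: the limit of > 100000 nM in this assay, at which 2 of the 2 values shown sit, so no order between the two measured compounds can be drawn and no step between them has been quantified. Compound 3 `O=C(Nc1cccc(Cl)c1)c1cc(Br)cc(Br)c1` has not yet been measured. It differs from compound 2 by chloro in place of hydrogen on an aromatic carbon, meta to a large group. Going by the values given here, with both measured values sitting at the limit, there is no measured step to build on. The step is expected to be a step that the limit leaves unreadable from compound 2 to compound 3, nothing beyond the scatter. Compound 3 is estimated at 150000 nM, ranging from 40000 nM to 600000 nM, and is expected most likely to return again only a limit.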

Compound 3, half-maximal inhibitory concentration: > 100000 nM
Compound 3: a limit, no number; the forecaster's own chance of this, stated with the estimate: 85%; the middle value does not contradict the limit.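

In this assay no step can be read from compound 1 or compound 2 to compound 3, as all three give only the same limit: the limit of > 100000 nM in this assay, at which 3 of the 3 values shown sit. The compounds shown leave open whether chloro or hydroxy on the shared core makes any difference to inhibition.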